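Swapping the Heteroaryl Thioether Cap in Jurkat Inhibitors

The source may report more compounds than this note shows. Statements on the series, on what has been measured and on what is new or still open speak of the compounds shown alone.

Measured so far in a functional assay on Jurkat cells (Homo sapiens) for inhibition; on this read-out lower numbers stand for stronger inhibition and higher numbers for weaker inhibition:
compound 1, `COC(=O)c1cc(OCC(=O)[C@H](CC(=O)O)NC(=O)[C@@H](NC(=O)COc2cccc3ccccc23)C(C)C)no1`, gives 71000 nM
compound 2, `CC(C)[C@H](NC(=O)COc1cccc2ccccc12)C(=O)N[C@@H](CC(=O)O)C(=O)CSc1nnc(-c2ccccc2)o1`, gives 150000 nM
compound 3, `CC(C)[C@H](NC(=O)COc1cccc2ccccc12)C(=O)N[C@@H](CC(=O)O)C(=O)CSc1nnnn1-c1ccccc1`, gives 153000 nM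

Compound 3 has the highest number of the three, though its gap to compound 2 is within the scatter; only compound 1 is clearly apart, as a 2.2-fold higher number from compound 1 to compound 3 (0.33 log units; beyond the scatter) shows. The three compounds share one core and differ only in the group carried on the saturated chain carbon bound to a carbonyl carbon.

Compound 4, `CC(C)[C@H](NC(=O)COc1cccc2ccccc12)C(=O)N[C@@H](CC(=O)O)C(=O)CSc1nccc(C(F)(F)F)n1`, keeps that core and changes the group on the sulfur: 4-(trifluoromethyl)pyrimidin-2-yl in place of 1-phenyl-1H-tetrazol-5-yl on a sulfur.

The step that bears most directly on this is a 1.0-fold higher number from compound 2 to compound 3 (0.01 log units; within the scatter), where one phenyl-bearing five-membered heteroaryl on the sulfur was exchanged for another without any shift beyond the scatter. The steps of a 2.1-fold higher number from compound 1 to compound 2 (0.32 log units; beyond the scatter) and a 2.2-fold higher number from compound 1 to compound 3 (0.33 log units; beyond the scatter) show that moving from the oxy-linked isoxazole of compound 1 to either sulfur-linked heteroaryl costs a modest amount. Within the data shown here, no measured compound carries a six-membered heteroaryl or a trifluoromethyl group on the sulfur, so there is no direct precedent.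

Compound 4 is therefore expected to stay close to compound 3, with a 1.2-fold lower number from compound 3 to compound 4 (0.07 log units; within the scatter), and the estimate for compound 4 is 130000 nM with a range from 50000 nM to 350000 nM.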

Compound 4, half-maximal inhibitory concentration: > 200000 nM
Compound 4: a limit, no number; the forecaster's own chance of this, stated with the estimate: 20%; middle value at least 1.5-fold (0.18 log units) from the limit.
By their numbers in this assay, from the lowest: compound 1; then compounds 2 and 3 (each within the scatter of the next). At a limit, above all of these: compound 4.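

In this assay compound 4 gives a limit and not a number, so its true value is not known: the limit of > 200000 nM in this assay, at which 1 of the 4 values shown sits.

Set against the two phenyl-bearing five-membered groups on the sulfur, this six-membered ring with its trifluoromethyl group shows no sign of a lower number, yet the floors of the steps to it (an at least 1.3-fold higher number from compound 3 to compound 4 (0.11 log units; that floor lies within the scatter) and an at least 1.3-fold higher number from compound 2 to compound 4 (0.12 log units; that floor lies within the scatter)) lie within the scatter, so compound 4 cannot be told apart from compound 2 or compound 3. The one clear separation is from the oxy-linked isoxazole (an at least 2.8-fold higher number from compound 1 to compound 4 (0.44 log units; beyond the scatter)), which extends what the earlier steps showed: all three sulfur-linked compounds, now including one with a quite different ring, sit on the weaker side of compound 1, and none of the compounds shown goes against this.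

The limit leaves open whether compound 4 lies close to compound 2 and compound 3 or far beyond them. It also leaves open which part of the new group counts, the pyrimidine ring or the trifluoromethyl, and a plain pyrimidin-2-yl or a 4-methylpyrimidin-2-yl on the sulfur would separate the two.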